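Ester to acid on two related ketone-bearing cores

The source may hold more compounds than are shown below. What is called first, only, known or untested is meant among the compounds shown, and "the series" means these compounds.

Compound 1 `COC(=O)c1ccc2ccc(C(=O)c3ccccc3)c-2cc1` gives 7.2% in an assay on cells for displacement of a labelled ligand from Orexin/Hypocretin receptor type 1 (Homo sapiens), read by scintillation counting, with stated times of 10 min and 90 min, tested at 10 uM; on this read-out higher numbers stand for more inhibition at the one concentration tested (going by the name of the read-out) and lower numbers for less inhibition. Compound 2 `O=C(O)c1ccc2ccc(C(=O)c3ccccc3)c-2cc1` carries hydrogen in place of methyl on an oxygen next to a carbonyl group relative to compound 1, and in this assay compound 2 gives 11%. The change made a step of a number 3.8 percentage points higher from compound 1 to compound 2 (within the scatter), so the two values lie close together.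

Compound 3 `COC(=O)c1cccc2c(C(=O)c3ccccc3)cc(C(=O)c3ccc(C(F)(F)F)cc3)c-2c1` rests on another core that also bears a methoxycarbonyl group; the difference between the two cores is not broken down here. In this assay compound 3 gives 10.4%, a value that sits close to that of compound 2 and to that of compound 1.

Compound 4 `O=C(O)c1cccc2c(C(=O)c3ccccc3)cc(C(=O)c3ccc(C(F)(F)F)cc3)c-2c1` has not yet been measured. It differs from compound 3 by hydrogen in place of methyl on an oxygen next to a carbonyl group, the same change that separates compound 1 from compound 2. For compound 4 a step of a number 2.6 percentage points higher from compound 3 to compound 4 (within the scatter) is expected, because the same change earlier gave a number 3.8 percentage points higher from compound 1 to compound 2 (within the scatter). Compound 4 is therefore expected to give about 13% in this assay, with a likely range from 3% to 23%.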

Compound 4, a percentage reported as inhibition, at one concentration (the size of the read-out at that concentration, not a potency): 18.3%
The estimate for compound 4 lay 5.3 percentage points below the measured number; the measured number falls inside the stated range.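

Going from methoxycarbonyl to carboxy on the core of compound 3 gave a step of a number 7.9 percentage points higher from compound 3 to compound 4 (within the scatter) in this assay. Set beside the step on the core of compound 1, this second step does not differ from the first by more than such pairs of steps usually scatter: the same change on two cores in this assay, a number 3.8 percentage points higher (within the scatter) from compound 1 to compound 2 and a number 7.9 percentage points higher (within the scatter) from compound 3 to compound 4, 4.1 percentage points apart, within the scatter of two such steps. The change therefore carries from one core to the other without a detectable difference, but this does not show that it has a real effect on either core, since each step lies within the scatter, and two cores read at one concentration say nothing about potency.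

The compounds shown leave open how an amide or an ethyl ester would read in this assay in place of the methoxycarbonyl or carboxy group. They also leave open whether an amine or a nitrile in place of the trifluoromethyl group would alter the values on the core of compound 3.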